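Trimethoxyphenyl for cyanophenyl on a second sulfonyl core

The compounds below may be only part of what the source reports. "The series", "measured", "known", "first", "only" and "open" are said of these compounds alone.

Compound 1 `N#Cc1ccc(/C=C2\CN(S(=O)(=O)c3ccc(F)cc3)C/C(=C\c3ccc(C#N)cc3)C2=O)cc1` gives 20100 nM in a functional assay on SMMC-7721 cells (Homo sapiens) for cytotoxicity, read by MTT assay, with a stated time of 24 h; a higher number here means a weaker inhibitor, a lower number a stronger inhibitor. Compound 2 `COc1cc(/C=C2\CN(S(=O)(=O)c3ccc(F)cc3)C/C(=C\c3ccc(C#N)cc3)C2=O)cc(OC)c1OC`, in this assay, gives 4120 nM; the change is 3,4,5-trimethoxyphenyl in place of 4-cyanophenyl on a double-bonded chain carbon bound to a double-bonded ring carbon, and the step is a 4.9-fold lower number from compound 1 to compound 2 (0.69 log units; beyond the scatter). Compound 3 `CC(=O)Nc1ccc(S(=O)(=O)N2C/C(=C\c3ccc(C#N)cc3)C(=O)/C(=C/c3ccccc3F)C2)cc1` sits on a different core; the difference between the two cores is not broken down here. In this assay compound 3 gives 3150 nM, the lowest of the three numbers, within the scatter of compound 2 and beyond it only against compound 1.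

Compound 4 `COc1cc(/C=C2\CN(S(=O)(=O)c3ccc(NC(C)=O)cc3)C/C(=C\c3ccccc3F)C2=O)cc(OC)c1OC` has not been measured. The change from compound 3 to compound 4 is 3,4,5-trimethoxyphenyl in place of 4-cyanophenyl on a double-bonded chain carbon bound to a double-bonded ring carbon: the same change as from compound 1 to compound 2, at the same place, made twice in all across these compounds. The step from compound 3 to compound 4 in this assay is expected to be a 3.5-fold lower number from compound 3 to compound 4 (0.54 log units; beyond the scatter), set beside the measured one from compound 1 to compound 2; the expectation rests on that single step only, tempered because compound 3 already gives 3150 nM and the cores differ. Compound 4 is expected to give about 900 nM, between 350 nM and 2500 nM.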

Compound 4, half-maximal inhibitory concentration: 3920 nM
Compound 4: middle estimate off by 4.4-fold (0.64 log units), on the low side; measured number outside the range, above it.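

In this assay, 3,4,5-trimethoxyphenyl in place of 4-cyanophenyl on a double-bonded chain carbon bound to a double-bonded ring carbon gives a 1.2-fold higher number from compound 3 to compound 4 (0.09 log units; within the scatter), so this pair cannot be told apart. The change therefore does not carry its effect from the core of compound 1 to the core of compound 3, and the two steps differ: the same change on two cores in this assay, a 4.9-fold lower number (0.69 log units; beyond the scatter) from compound 1 to compound 2 and a 1.2-fold higher number (0.09 log units; within the scatter) from compound 3 to compound 4, 6.1-fold (0.78 log units) apart, beyond the scatter of two such steps

This shows that the effect of the change depends on the core in these two pairs, but it does not show which of the several differences between the two cores is responsible, or how the change would behave on any third core.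

Going by these compounds, it remains open whether the step on each core would hold for another group at the same place, such as a dimethylaminophenyl or a carboxyphenyl. Also open, on these data alone, is which part of the core sets the size of the step, which would take pairs differing only in the group on the sulfonyl or only in the fluorophenyl.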